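Carboxy to ethynyl on the shared core

A few compounds are considered here, and "the series" means these few. Any claim that something is new, unique, unknown or untested is made for them only; others in the source may bear on it.

In a physicochemical assay for solubility, read by spectrophotometry, in phosphate buffer, with a stated time of 18 h, at pH 7.4 (on this read-out higher numbers stand for higher solubility and lower numbers for lower solubility), compound 2 `CCc1ccc(-c2nc3c(c(C)nn3-c3ccccc3)c(-c3ccccc3C(=O)O)c2C#N)cc1` gives 33000 nM, the highest of three numbers, ahead of compound 3 `CCc1ccc(-c2nc3c(c(C)nn3-c3ccccc3)c(-c3ccccc3OC(F)(F)F)c2C#N)cc1` at 9900 nM and compound 1 `CCc1ccc(-c2nc3c(c(C)nn3-c3ccccc3)c(-c3ccccc3O)c2C#N)cc1` at 3100 nM. Compound 4 `C#Cc1ccccc1-c1c(C#N)c(-c2ccc(CC)cc2)nc2c1c(C)nn2-c1ccccc1` carries ethynyl in place of carboxy on an aromatic carbon. Within the data shown here, no ethynyl compound has been measured, so only two steps that involve carboxy bear on this change, and neither matches it exactly. Going by an 11-fold higher number from compound 1 to compound 2 (1.03 log units; beyond the scatter), a large step, and a 3.3-fold lower number from compound 2 to compound 3 (0.52 log units; beyond the scatter), a modest one, both beyond the scatter, a modest to large drop in this assay is expected. For compound 4 the expected change is a 6.6-fold lower number from compound 2 to compound 4 (0.82 log units; beyond the scatter). Compound 4 is estimated at 5000 nM, within a range of 1500 nM to 16000 nM.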

Compound 4, solubility: 46000 nM
Compound 4: the middle estimate sits 9.2-fold (0.96 log units) below what was measured; the whole stated range lies below it.
By their numbers in this assay, from the lowest: compound 1; then compound 3; then compounds 2 and 4 (each within the scatter of the next).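

In this assay the 2-carboxyphenyl to 2-ethynylphenyl change gives a 1.4-fold higher number from compound 2 to compound 4 (0.14 log units; within the scatter), so a carboxy group is not required at this place for a number of this size. Ethynyl, which has no hydrogen-bond donor or acceptor, also stands clear of the other two groups, with a 4.6-fold higher number from compound 3 to compound 4 (0.67 log units; beyond the scatter) and a 15-fold higher number from compound 1 to compound 4 (1.17 log units; beyond the scatter). No measurement shown explains these results.

Open, from the compounds shown here alone, is whether an amine, a methyl group or a longer alkyne chain at this place stays level with compound 2 and compound 4. Also open, going by these compounds, is whether the ethynyl result holds on a different core.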